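Ethyl to Isopropyl on the Shared Core: a Small Step Expected

The source may hold more compounds than are shown below. What is called first, only, known or untested is meant among the compounds shown, and "the series" means these compounds.

Three compounds have so far been measured in a functional assay on cells for inhibition of Polyunsaturated fatty acid 5-lipoxygenase (Homo sapiens); on this read-out higher numbers stand for weaker inhibition and lower numbers for stronger inhibition:
Compound 1, `O=C1NCCN(c2cccc(Cl)c2)N1`: 2100 nM
Compound 2, `O=C1NCCN(c2cccc(OCc3ccccc3)c2)N1`: 200 nM
Compound 3, `CCC1CN(c2ccccc2)NC(=O)N1`: 3800 nM

Compound 3 gives the highest of the three numbers. Its nearest neighbour is compound 1, whose number lies lower by an amount that falls within the usual scatter, so the two cannot be told apart on this evidence. Compound 2 stands furthest away, with a number well below that of compound 3 and beyond the scatter. Among the measured compounds shown here, no pair among the measured compounds differs in a single place, so no measured step is available to lean on; the three values can only be read side by side.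

Compound 4, `CC(C)C1CN(c2ccccc2)NC(=O)N1`, differs from compound 3 in one place: methyl in place of hydrogen on a saturated chain carbon bound to a saturated chain carbon and a saturated ring carbon. For the measured compounds named here, nothing among the measured compounds shows what this change does on this core, so the expectation rests on the change being small and confined to a saturated chain carbon. The step from compound 3 to compound 4 is expected to be no change at the digits printed from compound 3 to compound 4 (within the scatter), that is, no change beyond the scatter, in either direction. Compound 4 is accordingly estimated at 3800 nM, with a range from 1500 nM to 9500 nM.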

Compound 4, half-maximal inhibitory concentration: 20000 nM
Beside the measured number, compound 4's estimate is 5.3-fold (0.72 log units) below it; measured number above the stated range.
By their numbers in this assay, from the lowest: compound 2; then compounds 1 and 3 (each within the scatter of the next); then compound 4.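

In this assay this place on the shared core proves sensitive to one added carbon: methyl in place of hydrogen on a saturated chain carbon bound to a saturated chain carbon and a saturated ring carbon brings a 5.3-fold higher number from compound 3 to compound 4 (0.72 log units; beyond the scatter), a move towards weaker inhibition. Among the compounds shown here, no earlier pair differed in a single place, so this is the first measured step on the core, and it shows that going from ethyl to isopropyl here is not a neutral exchange, even though only one heavy atom enters and no ring, hydrogen-bond donor, hydrogen-bond acceptor or charge comes with it. Nothing measured here bears on why the number rises.

The compounds shown leave open whether the number would keep rising with tert-butyl or with a longer chain such as n-butyl at this place, and whether a hydroxymethyl group or an amine there would behave differently. For the compounds shown here, they also leave open whether ethyl to isopropyl would give a step of similar size and direction when carried onto the core of compound 2, which shows the lowest number so far.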